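Methyl in place of fluoro on the urea aryl ring

The source may report more compounds than this note shows. Statements on the series, on what has been measured and on what is new or still open speak of the compounds shown alone.

In a functional assay on HT-29 cells (Homo sapiens) for antiproliferative activity, read by MTT assay, with a stated time of 48 h (on this read-out lower numbers stand for stronger inhibition and higher numbers for weaker inhibition), compound 3 `O=C(Nc1ccc(F)cc1)Nc1ccc(OC(=O)c2ccccc2)cc1` gives 94400 nM, the second highest of the three numbers, nearest to compound 1 `O=C(Nc1ccccc1)Nc1ccc(OC(=O)c2ccccc2)cc1` with 123000 nM and furthest from compound 2 `O=C(Nc1ccc(Cl)cc1)Nc1ccc(OC(=O)c2ccccc2)cc1` with 56000 nM. Compound 4 `Cc1ccc(NC(=O)Nc2ccc(OC(=O)c3ccccc3)cc2)cc1` differs from compound 3 by methyl in place of fluoro on an aromatic carbon. The measured steps at this position are all small: a 1.3-fold lower number from compound 1 to compound 3 (0.11 log units; within the scatter), a 2.2-fold lower number from compound 1 to compound 2 (0.34 log units; beyond the scatter) and a 1.7-fold higher number from compound 2 to compound 3 (0.23 log units; within the scatter). On that basis only a modest step, if any, is expected for compound 4 in this assay, and most likely none beyond the scatter. Compound 4 is therefore estimated at 70000 nM, with a range of 30000 nM to 160000 nM, which means an expected step of a 1.3-fold lower number from compound 3 to compound 4 (0.13 log units; within the scatter).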

Compound 4, half-maximal inhibitory concentration: 104000 nM
The estimate for compound 4 lay 1.5-fold (0.17 log units) below the measured number; the range from low to high includes it.
By their numbers in this assay, from the lowest: compounds 2, 3, 4 and 1 (each within the scatter of the next, the first and the last beyond it).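

Methyl at this place, para to a large group, gives a 1.1-fold higher number from compound 3 to compound 4 (0.04 log units; within the scatter) and a 1.9-fold higher number from compound 2 to compound 4 (0.27 log units; within the scatter) in this assay, and also a 1.2-fold lower number from compound 1 to compound 4 (0.07 log units; within the scatter). A carbon substituent thus joins fluoro in staying within the scatter of hydrogen, which leaves chloro, with a 2.2-fold lower number from compound 1 to compound 2 (0.34 log units; beyond the scatter), as the only replacement of hydrogen here to go beyond it. Nothing available bears on why these numbers lie so close.

From the compounds shown here alone, whether an amine, a carboxylic acid or a longer chain at this place would shift the number further stays open. So does whether the shared core responds more strongly to changes elsewhere.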